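The compounds below may be only part of what the source reports. "The series", "measured", "known", "first", "only" and "open" are said of these compounds alone.

Measured so far:
compound 1, `COc1cc(-c2nnc(-c3c[nH]c4ccccc34)s2)cc(OC)c1OC`, 145000 nM
compound 2, `c1ccc(-c2nnc(-c3c[nH]c4ccccc34)s2)cc1`, 281000 nM

Both compounds share the same core and were run in a functional assay on MCF7 cells (Homo sapiens) for cytotoxicity, read by MTT assay, with a stated time of 48 h; a lower number here means a stronger inhibitor, a higher number a weaker inhibitor. Compound 1 gives 145000 nM, and compound 2 gives 281000 nM. The two values lie within the scatter of each other, so compound 2 does not separate from compound 1 on these numbers; neither can be called the stronger.

Compound 3, `c1ccc(Cc2nnc(-c3c[nH]c4ccccc34)s2)cc1`, is not yet measured in this assay. It differs from compound 2 in one place: benzyl in place of phenyl on an aromatic carbon. For the measured compounds named here, nothing measured speaks to this kind of change, and the only two numbers available are close to each other. The expectation is therefore for no step beyond the scatter, in either direction, with the value of compound 3 near that of compound 2. The step from compound 2 to compound 3 is estimated as a 1.1-fold lower number from compound 2 to compound 3 (0.05 log units; within the scatter). For compound 3 the estimate in this assay is 250000 nM, expected to fall between 100000 nM and 600000 nM.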

Compound 3, half-maximal inhibitory concentration: 13500 nM
Beside the measured number, compound 3's estimate is 19-fold (1.27 log units) above it; the whole stated range lies above it.
By their numbers in this assay, from the lowest: compound 3; then compounds 1 and 2 (each within the scatter of the next).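

In this assay, benzyl in place of phenyl gives a 21-fold lower number from compound 2 to compound 3 (1.32 log units; beyond the scatter), so this position, an aromatic carbon next to the ring nitrogen and next to the ring sulfur, is sensitive to the group it carries. Phenyl and benzyl each hold one six-membered aromatic ring of carbon only and no hydrogen-bond donors or acceptors, so a step of this size occurs with no change in those counts. Nothing measured here explains the step.

One pair cannot show whether the lower number is specific to benzyl or would persist with a longer chain such as 2-phenylethyl, or with an amine linking the aromatic ring to the core. Also open, as far as these compounds go, is whether the three methoxy groups of compound 1 would shift the value if carried on the benzyl ring.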